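Swapping methyl for chloro in a growth inhibitor series

The source may hold more compounds than are shown below. What is called first, only, known or untested is meant among the compounds shown, and "the series" means these compounds.

Of the compounds shown here, two have been tested so far in a functional assay on NPC-TW01 cells (Homo sapiens) for inhibition, read by MTT assay, with a stated time of 72 h; a higher number here means a weaker inhibitor of growth, a lower number a stronger inhibitor of growth. Compound 1 `Nc1cc(-c2ccc(Cl)cc2)nn1-c1cccc(Cl)c1` returned only a limit, > 100000 nM, rather than a true number. Among the measured compounds shown here, compound 2 `Cc1ccc(-c2cc(N)n(-c3ccc(Br)cc3)n2)cc1` gives 80200 nM, the only actual number available, so it is the sole anchor for what follows.

The next molecule, compound 3 `Nc1cc(-c2ccc(Cl)cc2)nn1-c1ccc(Br)cc1`, differs from compound 2 in one place: chloro in place of methyl on an aromatic carbon. In words, chloro takes the place of methyl on an aromatic carbon, para to a large group. For the measured compounds named here, no measured pair yet shows what this swap does, so there is no direct guide to its size or direction in this assay. Without such a pair, the cautious expectation is no change beyond the usual scatter, taking compound 2 at 80200 nM as the starting point. The estimated step is a 1.1-fold lower number from compound 2 to compound 3 (0.06 log units; within the scatter), small and without a firm direction. For compound 3 the expected value is 70000 nM, with an estimated range of 30000 nM to 100000 nM.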

Compound 3, concentration for 50% growth inhibition: 64400 nM
The estimate for compound 3 lay 1.1-fold (0.04 log units) above the measured number, and the stated range covers the measured number.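

Among the compounds shown here, this is the first measured pair for this swap, and it gives a direct reading: in this assay, chloro in place of methyl on an aromatic carbon, para to a large group, gives a 1.2-fold lower number from compound 2 to compound 3 (0.10 log units; within the scatter). At this position, then, the two groups cannot be told apart in this assay, at least with the rest of the molecule held as in compound 2, and a single pair is all that supports this. Compound 1 stays a limit rather than a number, so it adds no measured step to set beside this one, and the only readable comparison remains the one pair: the limit of > 100000 nM in this assay, at which 1 of the 3 values shown sits.

The compounds shown leave open whether any group at this position can move the number beyond the scatter, since methyl and chloro are the only two seen there, and an amine, a carboxylic acid or a longer chain such as propyl could behave quite differently. They also leave open whether the same swap would stay this small on a compound that carries something other than the bromo group found in both compound 2 and compound 3.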